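A few compounds are considered here, and "the series" means these few. Any claim that something is new, unique, unknown or untested is made for them only; others in the source may bear on it.

Of the compounds shown here, two sharing one core have so far been read in a functional assay on MCF7 cells (Homo sapiens) for antiproliferative activity, read by MTT assay, with a stated time of 72 h; on this read-out lower numbers stand for stronger inhibition and higher numbers for weaker inhibition. Compound 1 (`CCOc1ccc(-c2ccc3ncn(-c4cc(OC)c(OC)c(OC)c4)c3c2)cc1`) gives 1710 nM on this read-out, and compound 2 (`COc1cc(-n2cnc3ccc(-c4ccc(C(C)=O)cc4)cc32)cc(OC)c1OC`) gives 1540 nM on the same read-out. Compound 2 therefore stands level with compound 1. Compound 3 (`COc1cc(-n2cnc3ccc(-c4ccc(C)cc4F)cc32)cc(OC)c1OC`) differs from compound 2 by 2-fluoro-4-methylphenyl in place of 4-acetylphenyl on an aromatic carbon on the shared core, which puts 2-fluoro-4-methylphenyl in place of 4-acetylphenyl on an aromatic carbon. Within the data shown here, only one measured step bears on this change, and only in part. It exchanged ethoxy for acetyl on the same phenyl ring, and at a 1.1-fold lower number from compound 1 to compound 2 (0.05 log units; within the scatter) it stayed within the scatter. Among the measured compounds shown here, no measured compound carries fluorine or methyl on that ring, so the data offer no direction for the new group. In this assay no step beyond the scatter is therefore expected. For the measured compounds named here, the estimated move is a 1.0-fold higher number from compound 2 to compound 3 (0.02 log units; within the scatter) and so remains small, although the single step available makes this a loose expectation. For compound 3 the expected value is 1600 nM within an estimated range from 500 nM to 5000 nM on this read-out.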

Compound 3, half-maximal inhibitory concentration: 56 nM
Compound 3: the middle estimate sits 29-fold (1.46 log units) above what was measured; the measured number lies below the stated range.
By their numbers in this assay, from the lowest: compound 3; then compounds 2 and 1 (each within the scatter of the next).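

In this assay, this aromatic carbon of the shared core, meta to a fused ring and para to a fused ring, proves highly sensitive to the phenyl group it carries: 2-fluoro-4-methylphenyl in place of 4-acetylphenyl gives a 28-fold lower number from compound 2 to compound 3 (1.44 log units; beyond the scatter), and the same group in place of 4-ethoxyphenyl gives a 31-fold lower number from compound 1 to compound 3 (1.48 log units; beyond the scatter). The earlier exchange of ethoxy for acetyl, a 1.1-fold lower number from compound 1 to compound 2 (0.05 log units; within the scatter), had shown no change beyond the scatter, so that step alone did not reveal how much the outcome at this position can depend on the group placed there. Nothing available here accounts for the gain seen with compound 3.

Compound 3 differs from the other two compounds in both the fluorine and the methyl, and it lacks their acetyl or ethoxy group, so the compounds shown cannot apportion the gain among these differences. Going by these compounds, it remains open how a phenyl ring with only 2-fluoro or only 4-methyl would behave here, and whether chlorine, an amine or a carboxylic acid on that ring would retain the low number of compound 3.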